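A few compounds are considered here, and "the series" means these few. Any claim that something is new, unique, unknown or untested is made for them only; others in the source may bear on it.

Working notes on the series. Three compounds have numbers in an assay on isolated protein for inhibition of DNA topoisomerase 1 (Homo sapiens), tested at 100 uM; a lower number here means a weaker effect, a higher number a stronger effect of the compound at the concentration tested. Compound 1 `Clc1ccc(-c2cc(-c3cccnc3)nc(-c3cccs3)c2)o1` gives 25.8% in this assay. Compound 2 `Cc1ccccc1-c1cc(-c2ccc(Cl)o2)cc(-c2ccsc2)n1` gives 6.7% in this assay. Compound 3 `Clc1ccc(-c2cc(-c3ccoc3)cc(-c3cccs3)n2)cc1` gives 0% in this assay. Compound 2 thus stands second highest of the three numbers: its nearest neighbour is compound 3, whose number lies within the scatter of it, while compound 1 stands beyond the scatter above it. Within the data shown here, compounds 1, 2 and 3 each differ from one another in more than one place, so no single step between measured compounds can be read from them.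

Compound 4 `Clc1cccc(-c2cc(-c3ccc(Cl)o3)cc(-c3ccsc3)n2)c1` has not yet been measured in this assay. It differs from compound 2 in one place: 3-chlorophenyl in place of 2-methylphenyl on an aromatic carbon Everything else of compound 2 is kept. Among the measured compounds shown here, since no measured pair differs in one place, the size of this step has no counterpart in the data; the two low numbers of compound 2 and compound 3 only show that this kind of compound sits near the bottom of the range seen so far. Expected is no step beyond the scatter in either direction, estimated as a number 1.3 percentage points higher from compound 2 to compound 4 (within the scatter). Compound 4 is estimated at 8% in this assay, with a range from 0% to 22%.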

Compound 4, a percentage reported as inhibition, at one concentration (the size of the read-out at that concentration, not a potency): 0%
Compound 4: the middle estimate sits 8 percentage points above what was measured, within the range that was stated.
By their numbers in this assay, from the lowest: compounds 3, 4 and 2 (each within the scatter of the next); then compound 1.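

Among these compounds, this is the first step that can be read at a single place: on the aromatic carbon next to the ring nitrogen, 3-chlorophenyl in place of 2-methylphenyl gives a number 6.7 percentage points lower from compound 2 to compound 4 (within the scatter) in this assay. At this position, then, the two substituted phenyl groups cannot be told apart in this assay, and neither the placement of the substituent on the phenyl ring nor the exchange of methyl for chlorine produces a step that can be separated from the scatter, with the rest of compound 2 kept. Nothing available in the series bears on this result or gives a reason for it.

Open, going by these compounds, is whether a group of a different kind at this position, such as a phenyl ring carrying an amine or a carboxylic acid, would give a step beyond the scatter from compound 2. Also open, on these data alone, is whether the same exchange would stay within the scatter if the thiophen-3-yl group or the 5-chlorofuran-2-yl group were replaced.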